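The source may report more compounds than this note shows. Statements on the series, on what has been measured and on what is new or still open speak of the compounds shown alone.

Working notes on the series. Compound 3 `Cc1ccc(Cn2cc(CSc3nc(Nc4ccccc4Cl)c(C#N)c(-c4ccccc4)n3)nn2)cc1` gives 11200 nM in a functional assay on ECa-109 cells (Homo sapiens) for inhibition, read by MTT assay, with a stated time of 72 h; a lower number here means a stronger inhibitor, a higher number a weaker inhibitor. Compound 1 `N#Cc1c(Nc2ccccc2Cl)nc(SCc2cn(Cc3ccccc3Cl)nn2)nc1-c1ccccc1` differs from compound 3 by 2-chlorophenyl in place of 4-methylphenyl on a saturated chain carbon bound to an aromatic nitrogen and in this assay compound 1 gives 28500 nM, a step of a 2.5-fold higher number from compound 3 to compound 1 (0.41 log units; beyond the scatter). Compound 2 `Cc1ccc(Cn2cc(CSc3nc(Nc4ccc(C)cc4)c(C#N)c(-c4ccccc4)n3)nn2)cc1` differs from compound 3 by 4-methylphenyl in place of 2-chlorophenyl on a nitrogen on an aromatic ring, and in this assay compound 2 gives 55700 nM; the step from compound 2 to compound 3 is a 5.0-fold lower number from compound 2 to compound 3 (0.70 log units; beyond the scatter). The gap between compound 2 and compound 1 lies within the scatter.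

Compound 4 `Cc1ccc(Nc2nc(SCc3cn(Cc4ccccc4Cl)nn3)nc(-c3ccccc3)c2C#N)cc1` is not yet measured. It differs from compound 2 by 2-chlorophenyl in place of 4-methylphenyl on a saturated chain carbon bound to an aromatic nitrogen. This is the same change as that from compound 3 to compound 1, at the same place, applied here to the core of compound 2 rather than the core of compound 3; the two cores differ by 4-methylphenyl in place of 2-chlorophenyl on a nitrogen on an aromatic ring.

The step from compound 2 to compound 4 is expected to be a 2.0-fold higher number from compound 2 to compound 4 (0.30 log units; within the scatter), resting on the step of a 2.5-fold higher number from compound 3 to compound 1 (0.41 log units; beyond the scatter) seen for the same change on the neighbouring core. Compound 4 is estimated at 110000 nM in this assay, in the range 45000 nM to 280000 nM, with a real chance that only a limit is reported.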

Compound 4, half-maximal inhibitory concentration: > 64000 nM
Compound 4 gave a limit, no number; the forecaster's own chance of this, stated with the estimate: 35%; the middle value is on the limit's open side.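

In this assay compound 4 carries a limit, > 64000 nM, and not a number. On the core of compound 2, the change from 4-methylbenzyl to 2-chlorobenzyl can be read only as an at least 1.1-fold higher number from compound 2 to compound 4 (0.06 log units; that floor lies within the scatter), which does not go against the rise seen on the core of compound 3 but shows neither its size nor that it carries over: the same change on two cores in this assay, a 2.5-fold higher number (0.41 log units; beyond the scatter) from compound 3 to compound 1 and an at least 1.1-fold higher number (0.06 log units; that floor lies within the scatter) from compound 2 to compound 4; the limit leaves it open whether they differ. The change from 2-chlorophenyl to 4-methylphenyl on a nitrogen on an aromatic ring reads as an at least 2.2-fold higher number from compound 1 to compound 4 (0.35 log units; beyond the scatter), so it raises the number on both cores, though equal size on the two cores is not shown: the same change on two cores in this assay, a 5.0-fold lower number (0.70 log units; beyond the scatter) from compound 2 to compound 3 and an at least 2.2-fold lower number (0.35 log units; beyond the scatter) from compound 4 to compound 1; the limit leaves it open whether they differ.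

From the compounds shown here alone, it remains open how far compound 4 lies past its limit, and so whether the benzyl change on the core of compound 2 exceeds the scatter at all. Also open, going by these compounds, is how a plain benzyl, or a chain ending in an amine or a carboxylic acid, would behave at that place on either core.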